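Microsomal clearance from compound 2 to compound 3

The compounds below may be only part of what the source reports. "The series", "measured", "known", "first", "only" and "open" are said of these compounds alone.

In an ADME assay on microsomes from liver (Homo sapiens) for metabolic stability, read by LC-MS, tested at 1 uM (on this read-out higher numbers stand for fast clearance and lower numbers for slow clearance), compound 1 `CC(C)(O)CNCCCOc1ccc([C@H]2CC[C@]3(CC2)OOC2(O3)C3CC4CC(C3)CC2C4)cc1` gives 8 mL.min-1.g-1. Compound 2 `NC1CCN(S(=O)(=O)c2ccc([C@H]3CC[C@]4(CC3)OOC3(O4)C4CC5CC(C4)CC3C5)cc2)CC1` gives < 7 mL.min-1.g-1, which is a limit of the assay and not a number. Compound 3 `c1cc([C@H]2CC[C@]3(CC2)OOC2(O3)C3CC4CC(C3)CC2C4)ccc1OCC1CCNCC1` has (piperidin-4-yl)methoxy in place of (4-aminopiperidin-1-yl)sulfonyl on an aromatic carbon, para to a large group ((piperidin-4-yl)methoxy in place of (4-aminopiperidin-1-yl)sulfonyl on an aromatic carbon). Among the measured compounds shown here, one measured step bears on this position: an at least 1.1-fold lower number from compound 1 to compound 2 (0.05 log units; that floor lies within the scatter). On that single step, no change beyond the scatter is expected in this assay, in either direction. The expected step is an at least 1.1-fold higher number from compound 2 to compound 3 (0.05 log units; that floor lies within the scatter). Compound 3 is estimated at 8 mL.min-1.g-1, with an expected range of 4 mL.min-1.g-1 to 18 mL.min-1.g-1.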

Compound 3, intrinsic clearance in microsomes: < 7 mL.min-1.g-1
Compound 3: no number, only a limit; the forecaster's own chance of this, stated with the estimate: 40%; middle value at least 1.1-fold (0.05 log units) away from the limit.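

In this assay compound 3 gives < 7 mL.min-1.g-1, which is a limit and not a number. Set against compound 1, the change of side chain gives an at least 1.1-fold lower number from compound 1 to compound 3 (0.05 log units; that floor lies within the scatter), so this position takes a second group, (piperidin-4-yl)methoxy, without a step beyond the scatter. The step between compound 2 and compound 3 cannot be read, and the read-out does not separate these two groups: the limit of < 7 mL.min-1.g-1 in this assay, at which 2 of the 3 values shown sit.

Still open, going by these compounds, is whether a carboxylic acid or a longer chain on this aromatic carbon would give a number rather than a limit.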